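A few compounds are considered here, and "the series" means these few. Any claim that something is new, unique, unknown or untested is made for them only; others in the source may bear on it.

Two compounds of this series carry results in a functional assay on the whole organism (strain CF-1) for inhibition, with Mus musculus as the target; on this read-out lower numbers stand for an effect already at smaller amounts and higher numbers for an effect only at larger amounts of compound. Compound 1 `Cc1nnc(CN2CCCC2)n1-c1ccc(Cl)cc1Cc1ccccc1` reaches only > 100 mg/kg in this assay, and that figure is a limit of the assay rather than a measured number. Compound 2 `CN(C)Cc1nnc(-c2ccco2)n1-c1ccc(Cl)cc1C(=O)c1ccccc1` gives 23 mg/kg in this assay. Among the measured compounds shown here, compound 2 therefore holds the only number in the set. The remaining value sits at the limit of > 100 mg/kg in this assay, at which 1 of the 2 values shown sits. Compound 1 and compound 2 differ from each other in more than one place, so their two values show no more than that one yields a number and the other a limit.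

The unmeasured compound 3 `Cc1nnc(CN(C)C)n1-c1ccc(Cl)cc1C(=O)c1ccccc1` departs from compound 2 by a single change: methyl in place of furan-2-yl on an aromatic carbon. For the measured compounds named here, no measured pair in this set isolates that change, so the step has to be guessed. The writer expects a step from compound 2 to compound 3 of a 2.0-fold higher number from compound 2 to compound 3 (0.29 log units; within the scatter), a modest weakening that may or may not exceed the scatter, with a real chance that only a limit is reported. For compound 3 the estimate in this assay is 45 mg/kg, with a range from 15 mg/kg to 150 mg/kg.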

Compound 3, dose for half-maximal effect: 1.1 mg/kg
Compound 3: the middle estimate sits 41-fold (1.61 log units) above what was measured, and the stated range ends above it.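

In this assay, the group on this aromatic carbon, between two ring nitrogen atoms, proves to have a large bearing on the read-out: methyl in place of furan-2-yl gives a 21-fold lower number from compound 2 to compound 3 (1.32 log units; beyond the scatter). Among the compounds shown here, this is the first step in the set that isolates a single change, which the two earlier compounds, differing in more than one place, could not do, and it shows that at this position the group with one heavy atom and no ring gives the lower number of the two groups compared. Nothing measured here accounts for the size of this step.

The compounds shown leave open whether the lower number is particular to methyl or would also appear with other groups on this carbon, such as ethyl, a cyclopropyl ring or a single hydrogen atom. From the compounds shown here alone, it also remains open whether the same change would have a step of similar size with a group other than (dimethylamino)methyl on the ring, such as a pyrrolidin-1-ylmethyl group.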